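Acylation of the ring amine in the triazolopyrimidine series

The source may report more compounds than this note shows. Statements on the series, on what has been measured and on what is new or still open speak of the compounds shown alone.

Of the compounds shown here, three sharing one core have been measured in an assay on isolated protein for binding affinity to adenosine receptor A1 (Bos taurus); a higher number here means a weaker inhibitor, a lower number a stronger inhibitor. Compound 1 `Clc1ccccc1Cn1nnc2c(NC3CCC3)nc(-c3ccccc3)nc21` gives 24000000 nM. Compound 2 `CCCCCCNc1nc(-c2ccccc2)nc2c1nnn2Cc1ccccc1Cl` gives 31000000 nM. Compound 3 `Clc1ccccc1Cn1nnc2c(NC3CCCCC3)nc(-c3ccccc3)nc21` gives 34000000 nM, the largest of the three numbers, but the separations are small: a 1.4-fold higher number from compound 1 to compound 3 (0.15 log units; within the scatter) and a 1.1-fold higher number from compound 2 to compound 3 (0.04 log units; within the scatter), both within the scatter, as is a 1.3-fold higher number from compound 1 to compound 2 (0.11 log units; within the scatter). Across cyclobutyl, hexyl and cyclohexyl on the ring nitrogen the readings therefore do not differ in any resolvable way.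

Compound 4 `COc1ccc(C(=O)Nc2nc(-c3ccccc3)nc3c2nnn3Cc2ccccc2Cl)cc1` has not yet been measured in this assay. Relative to compound 3 the change is (4-methoxyphenyl)carbonyl in place of cyclohexyl on a nitrogen on an aromatic ring. None of the three measured steps bears on it directly: all three exchange one alkyl or cycloalkyl group for another, and all three stay within the scatter. Within the data shown here, no step in which an acyl group enters on the ring nitrogen exists in this set, so the direction of any effect is unknown.

Among the measured compounds shown here, with no guiding step, compound 4 is expected to land near the measured values, at an estimated 30000000 nM with a range of 8000000 nM to 120000000 nM. As far as these compounds go, the implied step is expected to be a 1.1-fold lower number from compound 3 to compound 4 (0.05 log units; within the scatter), with a widened range because the acyl change is untested here.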

Compound 4, inhibition constant: 20000000 nM
Compound 4: middle estimate off by 1.5-fold (0.18 log units), on the high side, within the range that was stated.
By their numbers in this assay, from the lowest: compounds 4, 1, 2 and 3 (each within the scatter of the next).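

In this assay, (4-methoxyphenyl)carbonyl on a nitrogen on an aromatic ring gives no resolvable shift against any of the three alkyl or cycloalkyl groups (a 1.7-fold lower number from compound 3 to compound 4 (0.23 log units; within the scatter); a 1.6-fold lower number from compound 2 to compound 4 (0.19 log units; within the scatter); a 1.2-fold lower number from compound 1 to compound 4 (0.08 log units; within the scatter)), so this position now has an acylated member that reads the same as the others within the scatter. The exchange from cyclohexylamino to ((4-methoxyphenyl)carbonyl)amino replaces a non-aromatic carbon ring with an aromatic one and brings in a carbonyl and hydrogen-bond acceptors, a larger structural change than any step among compounds 1, 2 and 3, yet the reading still does not separate from theirs. Nothing available explains this flat response at the position.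

The compounds shown leave open whether any group on this nitrogen can move the reading beyond the scatter, for example a free amine, an acetyl group or a benzoyl group without the methoxy. They also leave open whether the methoxy or the carbonyl matters on its own, which a benzyl group in place of the acyl group or a hydroxy in place of the methoxy would begin to separate.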